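This account rests on a few compounds, and the source may have more. Where it says the series, first, only, none or still open, it means among the compounds named here.

Of the compounds shown here, two share one core and have been tested in a functional assay on M21 cells (Homo sapiens) for antiproliferative activity, read by sulforhodamine B assay, with a stated time of 48 h; on this read-out lower numbers stand for stronger inhibition and higher numbers for weaker inhibition. Compound 1, `CC(=O)Nc1ccc(S(=O)(=O)Oc2ccccc2C(C)C)cc1`, gives 21000 nM in this assay. Compound 2, `CCNC(=O)Nc1ccc(S(=O)(=O)Oc2ccccc2I)cc1`, gives 5600 nM in this assay. Of these two numbers, compound 1 stands at the higher end, and the gap to compound 2 lies beyond the scatter of repeated measurements, so compound 1 is the weaker inhibitor of the pair. Compound 2 differs from compound 1 in two places at once, so its lower number cannot be assigned to either change alone.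

Compound 3, `CCCNC(=O)Nc1ccc(S(=O)(=O)Oc2ccccc2C(C)C)cc1`, has not yet been measured. It differs from compound 1 in a single place: propylamino in place of methyl on a carbonyl carbon. Cut one bond further out, the change reads acetamido to (propylcarbamoyl)amino. Among the compounds with values here, compound 2 also carries a carbamoylamino group and sits lower than compound 1, which hints at a downward direction, but no measured step isolates this change. A moderate step downward, somewhat beyond the scatter, is expected, a 3.0-fold lower number from compound 1 to compound 3 (0.48 log units; beyond the scatter). Compound 3 is expected to give about 7000 nM in this assay, with a range from 2000 nM to 25000 nM.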

Compound 3, half-maximal inhibitory concentration: 5100 nM
Estimate against measurement, compound 3: 1.4-fold (0.14 log units) above; the measured number falls inside the stated range.
By their numbers in this assay, from the lowest: compounds 3 and 2 (each within the scatter of the next); then compound 1.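

In this assay, putting propylamino in place of methyl on a carbonyl carbon gives a 4.1-fold lower number from compound 1 to compound 3 (0.61 log units; beyond the scatter). Within the data shown here, this is the first step that changes only one place, so this drop, which lies beyond the scatter, can be tied directly to the change from acetamido to (propylcarbamoyl)amino, something the two changes made at once between compound 1 and compound 2 did not allow. Nothing available here explains why this change lowers the number.

The change brings in an amide-type nitrogen and a three-carbon propyl chain together, so the compounds shown leave open whether the lower number follows the added nitrogen, the chain or the two combined; a butyl group on the carbonyl carbon without the nitrogen, or a shorter methylamino or longer butylamino group in the same place, would help separate these. On these data alone, it also remains open whether this step would keep its size on a core bearing a different group elsewhere, such as a bromine atom in place of the iodine of compound 2.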